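Removing the ring-nitrogen acyl group from compound 1

The source may hold more compounds than are shown below. What is called first, only, known or untested is meant among the compounds shown, and "the series" means these compounds.

Of the compounds shown here, three sharing one core have been measured in a functional assay on NCI-H23 cells (Homo sapiens) for cytotoxicity, read by sulforhodamine B assay, with a stated time of 72 h; on this read-out lower numbers stand for stronger inhibition of growth and higher numbers for weaker inhibition of growth. Compound 1 `O=C(Nc1cc(C(F)(F)F)cc(C(F)(F)F)c1)C1CCc2ccccc2N1C(=O)c1ccccc1Cl` gives 2080 nM, the lowest of the three numbers. Compound 3 `O=C(Nc1ccccc1O)C1CCc2ccccc2N1` gives 2230 nM, a value within the scatter of that of compound 1, so the two cannot be ranked. Compound 2 `CCCCCCCCC(=O)N1c2ccccc2CCC1C(=O)Nc1ccccc1C(F)(F)F` gives 4220 nM, which lies beyond the scatter above compound 1. Compound 4 `O=C(Nc1cc(C(F)(F)F)cc(C(F)(F)F)c1)C1CCc2ccccc2N1` has not been measured in this assay. It differs from compound 1 in one place: hydrogen in place of (2-chlorophenyl)carbonyl on a nitrogen on an aromatic ring in a ring. For the measured compounds named here, no step between measured compounds isolates this change. The closest guide is compound 3, which also carries hydrogen on that ring nitrogen and gives 2230 nM, a number close to that of compound 1 despite a different anilide. The step from compound 1 to compound 4 is therefore expected to be small, in either direction, and not beyond the scatter: a 1.2-fold higher number from compound 1 to compound 4 (0.08 log units; within the scatter). Compound 4 is estimated at 2500 nM, with a range from 800 nM to 8000 nM.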

Compound 4, concentration for 50% growth inhibition: 8410 nM
Estimate against measurement, compound 4: 3.4-fold (0.53 log units) below; measured number outside the range, above it.
By their numbers in this assay, from the lowest: compounds 1, 3, 2 and 4 (each within the scatter of the next, the first and the last beyond it).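

With the anilide of compound 1 held fixed, replacing (2-chlorophenyl)carbonyl with hydrogen on the ring nitrogen gives a 4.0-fold higher number from compound 1 to compound 4 (0.61 log units; beyond the scatter) in this assay, so the group on this nitrogen does affect the read-out. The earlier compounds shown here differed from each other in more than one place and could not show this, whereas this step isolates the change. Nothing available explains why the number rises when the group is removed.

Going by these compounds, it remains open whether the step depends on the carbonyl, the aromatic ring or the chlorine of the departing group, which an acetyl or benzyl group on that nitrogen would help to separate. On these data alone, it is also open whether the same change would give a step of similar size with the anilide of compound 2 or compound 3.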